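Hydroxy-oxopiperidinyl versus sultam on the fused aryl ring

The compounds below may be only part of what the source reports. "The series", "measured", "known", "first", "only" and "open" are said of these compounds alone.

Measured so far:
compound 1 `CC(C)c1noc(N2CCC(Oc3cc(N4CCc5cc(N6CC(O)CCC6=O)ccc54)ncn3)CC2)n1` — 90 nM
compound 2 `CC(C)c1noc(N2CCC(Oc3cc(N4CCc5cc(N6CCCS6(=O)=O)ccc54)ncn3)CC2)n1` — 9.7 nM
compound 3 `CC(C)SC(=O)N1CCC(Oc2cc(N3CCc4cc(S(C)(=O)=O)ccc43)ncn2)CC1` — 3.2 nM

In an assay on CHO cells for agonist activity at Glucose-dependent insulinotropic receptor (Homo sapiens), read by a luciferase reporter and cAMP accumulation, with a stated time of 2 h (on this read-out lower numbers stand for an effect already at smaller amounts and higher numbers for an effect only at larger amounts of compound), compound 2 stands second of the three numbers; compound 3 gives 3.2 nM, and compound 1 gives 90 nM. For the measured compounds named here, the shared core of compound 1 and compound 2 is the same, and the one measured step that bears on the present question is a 9.3-fold lower number from compound 1 to compound 2 (0.97 log units; beyond the scatter), in which the sultam replaced a hydroxylated six-membered ring of the same composition as the one now considered.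

Compound 4 `CC(C)c1noc(N2CCC(Oc3cc(N4CCc5cc(N6CCC(O)CC6=O)ccc54)ncn3)CC2)n1` is not yet measured. It differs from compound 2 in one place: a group of 8 heavy atoms (5 carbon, 1 nitrogen, 2 oxygen; one six-membered non-aromatic ring with 1 hetero atom) in place of a group of 7 heavy atoms (3 carbon, 1 nitrogen, 2 oxygen, 1 sulfur; one five-membered non-aromatic ring with 2 hetero atoms), on an aromatic carbon. Going by the values given here, the group entering compound 4 has the same atom and ring count as the group that left in the step from compound 1 to compound 2, with the hydroxyl on a different ring carbon; compound 1 is the only comparison for this type of group, and no measured pair separates the two hydroxyl placements.

Because compound 1 gives 90 nM while compound 2 gives 9.7 nM, the return to a hydroxy-oxopiperidinyl ring in compound 4 is expected to move the number back upward by roughly a 5.2-fold higher number from compound 2 to compound 4 (0.71 log units; beyond the scatter). Compound 4 is therefore estimated at 50 nM, with a range of 15 nM to 160 nM in this assay.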

Compound 4, half-maximal effective concentration: 89 nM
Estimate against measurement, compound 4: 1.8-fold (0.25 log units) below; measured number inside the range.
By their numbers in this assay, from the lowest: compound 3; then compound 2; then compounds 4 and 1 (each within the scatter of the next).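

In this assay, the placement of the hydroxyl on the six-membered ring at this aromatic carbon makes no measurable difference: 4-hydroxy-2-oxopiperidin-1-yl in place of 5-hydroxy-2-oxopiperidin-1-yl gives a 1.0-fold lower number from compound 1 to compound 4 (0.00 log units; within the scatter). The sultam of compound 2 now stands against two hydroxylated rings rather than one, with a 9.2-fold higher number from compound 2 to compound 4 (0.96 log units; beyond the scatter) alongside the earlier 9.3-fold lower number from compound 1 to compound 2 (0.97 log units; beyond the scatter), so the higher number goes with both hydroxyl placements and not with a single one. The compounds shown offer no measurement that accounts for this difference.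

Each exchange with the sultam changes the ring size, the sulfonyl group and the hydroxyl together, so what the compounds shown leave open is which of these changes carries the step. A plain 2-oxopiperidin-1-yl ring without the hydroxyl would address the hydroxyl alone, and a six-membered ring bearing the sulfonyl group would address the ring size alone.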